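A few compounds are considered here, and "the series" means these few. Any claim that something is new, unique, unknown or untested is made for them only; others in the source may bear on it.

Measured so far:
- compound 1, `Cc1cccc(-n2cc(COc3cccc(NC(=O)Nc4ccc(Cl)c(C(F)(F)F)c4)c3)nn2)c1`, 7270 nM
- compound 2, `CCc1ccccc1-n1cc(COc2cccc(NC(=O)Nc3ccc(Cl)c(C(F)(F)F)c3)c2)nn1`, 3530 nM
- compound 3, `O=C(Nc1cccc(OCc2cn(-c3cccc(Cl)c3)nn2)c1)Nc1ccc(Cl)c(C(F)(F)F)c1`, 2020 nM

In a functional assay on HepG2 cells (Homo sapiens) for inhibition, read by MTT assay, with a stated time of 72 h (a lower number here means a stronger inhibitor, a higher number a weaker inhibitor), compound 1 gives the highest number of the three. Its nearest neighbour is compound 2, reached by a 2.1-fold lower number from compound 1 to compound 2 (0.31 log units; beyond the scatter); furthest is compound 3, reached by a 3.6-fold lower number from compound 1 to compound 3 (0.56 log units; beyond the scatter). Between compound 2 and compound 3 the step is a 1.7-fold lower number from compound 2 to compound 3 (0.24 log units; within the scatter).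

Compound 4, `O=C(Nc1cccc(OCc2cn(-c3ccc(Br)cc3)nn2)c1)Nc1ccc(Cl)c(C(F)(F)F)c1`, has not yet been measured. It differs from compound 1 in one place: 4-bromophenyl in place of 3-methylphenyl on an aromatic nitrogen.

Within the data shown here, two measured steps bear on this change. The step from compound 1 to compound 3 also replaces the methyl on the ring attached to the aromatic nitrogen with a halogen, and it gave a 3.6-fold lower number from compound 1 to compound 3 (0.56 log units; beyond the scatter). The step from compound 1 to compound 2 changes the same ring in another way and gave a 2.1-fold lower number from compound 1 to compound 2 (0.31 log units; beyond the scatter). Both point the same way, so compound 4 is expected to give a lower number than compound 1 in this assay, by a modest step, a 2.8-fold lower number from compound 1 to compound 4 (0.45 log units; beyond the scatter). For compound 4 the estimate is 2600 nM, with a range of 1200 nM to 5600 nM.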

Compound 4, half-maximal inhibitory concentration: 2730 nM
Compound 4: the middle estimate sits 1.1-fold (0.02 log units) below what was measured, and the stated range covers the measured number.
By their numbers in this assay, from the lowest: compounds 3, 4 and 2 (each within the scatter of the next); then compound 1.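

In this assay the 4-bromophenyl group on the aromatic nitrogen also moves away from the 3-methylphenyl of compound 1, with a 2.7-fold lower number from compound 1 to compound 4 (0.43 log units; beyond the scatter) in a modest step, so a lower number at this position is now seen with bromine as well as chlorine on the ring. Against the other two groups, the change gives a 1.4-fold higher number from compound 3 to compound 4 (0.13 log units; within the scatter) and a 1.3-fold lower number from compound 2 to compound 4 (0.11 log units; within the scatter) and so cannot separate 4-bromophenyl from 3-chlorophenyl or 2-ethylphenyl; of the four groups, only 3-methylphenyl stands apart. Nothing measured here accounts for these numbers.

The compounds shown leave open how a phenyl ring bearing an amine or a carboxylic acid would read in this assay at this position. Also open, from the compounds shown here alone, is whether 3-bromophenyl or 4-chlorophenyl would match the two halogen compounds, which would show whether the identity of the halogen or its place on the ring matters.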